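A few compounds are considered here, and "the series" means these few. Any claim that something is new, unique, unknown or untested is made for them only; others in the source may bear on it.

Compounds measured in a functional assay on NCI-H460 cells (Homo sapiens) for antiproliferative activity, with a stated time of 72 h; a higher number here means a weaker inhibitor, a lower number a stronger inhibitor:
- compound 1, `C=CC[C@H]1C[C@]2([C@@H](C)Cc3ccc(OC)c(C)c3)OCOC2=CC1=O`, giving 630 nM
- compound 2, `C=CC[C@H]1C[C@]2([C@@H](C)Cc3ccc(OC)c(C#N)c3)OCOC2=CC1=O`, giving 340 nM
- compound 3, `C=CC[C@H]1C[C@]2([C@@H](C)Cc3cc(C)c(OC)cc3F)OCOC2=CC1=O`, giving 650 nM

Compound 3 carries the highest of the three numbers, but its gap to compound 1 and to compound 2 is within the scatter, so the three measured compounds cannot be ordered against each other. The step from compound 1 to compound 2 in this assay, a 1.9-fold lower number from compound 1 to compound 2 (0.27 log units; within the scatter), and the step from compound 1 to compound 3, a 1.0-fold higher number from compound 1 to compound 3 (0.01 log units; within the scatter), both stay within the scatter: neither exchange on the aromatic ring moved the read-out.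

Compound 4, `C=CC[C@H]1C[C@]2([C@@H](C)Cc3cc(N)c(OC)cc3F)OCOC2=CC1=O`, differs from compound 3 by amino in place of methyl on an aromatic carbon; the place is ortho to a methoxy group, meta to a large group and para to a fluoro group. Among the measured compounds shown here, no measured pair exchanges methyl for amino, so the step has no direct precedent. The two measured steps on the same ring were both within the scatter, which gives no reason to expect a shift beyond it here.

Compound 4 is therefore expected to give about 600 nM in this assay, estimated between 250 nM and 1500 nM, that is an expected step of a 1.1-fold lower number from compound 3 to compound 4 (0.03 log units; within the scatter).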

Compound 4, half-maximal inhibitory concentration: 160 nM
For compound 4 the middle estimate is 3.8-fold (0.57 log units) above the measured one; measured number below the stated range.
By their numbers in this assay, from the lowest: compound 4; then compounds 2, 1 and 3 (each within the scatter of the next).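

In this assay, among the compounds shown here, amino in place of methyl on the aromatic carbon ortho to a methoxy group, meta to a large group and para to a fluoro group gives a 4.1-fold lower number from compound 3 to compound 4 (0.61 log units; beyond the scatter) and is the only step printed as beyond the scatter. The ring substitution is therefore not uniformly silent in this read-out: cyano in place of methyl and fluoro in place of hydrogen left the number within the scatter, whereas this one-atom exchange, which replaces a group with no hydrogen-bond donor or acceptor by one that has both, does not. No measurement shown here connects the step to any particular property of the amino group.

The compounds shown do not settle whether the step is specific to amino or would also appear with a hydroxyl, an acetamide or a dimethylamino group at the same place. They also leave open whether amino gives a comparable step on the ring without the fluoro group, as an exchange for the methyl of compound 1.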